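Allenic amines and monoamine oxidase: a ring chloro step

The source may report more compounds than this note shows. Statements on the series, on what has been measured and on what is new or still open speak of the compounds shown alone.

Compound 1 `C=C=C(Cc1ccccc1)CN(C)C` carries a dimethylamino group; in an assay on isolated protein for inhibition of Monoamine oxidase (Rattus norvegicus) (a lower number here means a stronger inhibitor, a higher number a weaker inhibitor), compound 1 gives 25000 nM. Compound 2 `C=C=C(CN)Cc1ccccc1` carries the primary amino group instead, and in this assay compound 2 gives 20000 nM. The step of a 1.3-fold lower number from compound 1 to compound 2 (0.10 log units; within the scatter) puts the two values within the scatter of each other, so compound 2 stands beside compound 1 with no separation that the numbers can support. Compound 3 `C=C=C(CN)Cc1ccc(Cl)cc1` differs from compound 2 by chloro in place of hydrogen on an aromatic carbon. Within the data shown here, no measured step touches the aromatic ring; the single measured step, a 1.3-fold lower number from compound 1 to compound 2 (0.10 log units; within the scatter), concerns the amine and gives no guide to a ring substituent. The expectation for compound 3 in this assay therefore rests on compound 2 alone, with a 1.3-fold lower number from compound 2 to compound 3 (0.12 log units; within the scatter) expected to stay near the scatter and its direction open. Compound 3 is estimated at 15000 nM, within a range from 4000 nM to 50000 nM.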

Compound 3, half-maximal inhibitory concentration: 260 nM
Beside the measured number, compound 3's estimate is 58-fold (1.76 log units) above it; the measured number lies below the stated range.
By their numbers in this assay, from the lowest: compound 3; then compounds 2 and 1 (each within the scatter of the next).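

Chloro in place of hydrogen on an aromatic carbon, para to a group of 6 heavy atoms, is the first change in the series to move the number in this assay beyond the scatter: a 77-fold lower number from compound 2 to compound 3 (1.89 log units; beyond the scatter). Among these compounds, the amine step, a 1.3-fold lower number from compound 1 to compound 2 (0.10 log units; within the scatter), stayed within the scatter, so this ring position shows a sensitivity that the earlier compounds did not reveal, and it does so with a single added heavy atom. Nothing among the data shown accounts for the size of this step.

Open, going by these compounds, is whether the step belongs to chloro itself: fluoro, bromo or methyl at the same position would test that, as would chloro on another ring carbon. Also open, on these data alone, is whether dimethylamino in place of the amino group of compound 3 would stay within the scatter, as it did without the chloro.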